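Replacing 4-methylphenyl with methyl in compound 2

A few compounds are considered here, and "the series" means these few. Any claim that something is new, unique, unknown or untested is made for them only; others in the source may bear on it.

Measured in an ADME assay on cells (Hepatocyte, Homo sapiens) for metabolic stability, with a stated time of 30 min; a lower number here means that less of the compound is left, a higher number that more of the compound is left
- compound 1 `O=C(OC1CCC(CN2CCN(c3cc(=O)c4cc(C(F)(F)F)cc([N+](=O)[O-])c4s3)CC2)CC1)c1ccccc1` gives 56.4%
- compound 2 `Cc1ccc(C(=O)OC2CCC(CN3CCN(c4cc(=O)c5cc(C(F)(F)F)cc([N+](=O)[O-])c5s4)CC3)CC2)cc1` gives 9.7%

Compound 2 stands lowest of the two, at 9.7%, so little of it is left. Compound 3 `CC(=O)OC1CCC(CN2CCN(c3cc(=O)c4cc(C(F)(F)F)cc([N+](=O)[O-])c4s3)CC2)CC1` differs from it as follows: methyl in place of 4-methylphenyl on a carbonyl carbon, which is methyl in place of 4-methylphenyl on a carbonyl carbon. Among the measured compounds shown here, only one measured step bears on this, and only loosely. The step of a number 46.7 percentage points lower from compound 1 to compound 2 (beyond the scatter) is large, yet it is methyl in place of hydrogen on an aromatic carbon, a different change. For the measured compounds named here, it shows that this assay can move strongly within this small set, but no measured step shows what losing the 4-methylphenyl does. Compound 2 at 9.7% has far more room above than below, so a moderate rise is expected, with wide uncertainty. The estimated step is a number 20.3 percentage points higher from compound 2 to compound 3 (beyond the scatter). For compound 3 the estimated value is 30%, with an expected range from 5% to 65%.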

Compound 3, percent of the compound remaining: 0%
Beside the measured number, compound 3's estimate is 30 percentage points above it; measured number outside the range, below it.
By their numbers in this assay, from the lowest: compounds 3 and 2 (each within the scatter of the next); then compound 1.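

In this assay, putting methyl in place of 4-methylphenyl on the carbonyl carbon gives no change that can be told from the scatter, with a number 9.7 percentage points lower from compound 2 to compound 3 (within the scatter). Methyl in place of phenyl on that same carbon gives a large change, with a number 56.4 percentage points lower from compound 1 to compound 3 (beyond the scatter), so an aromatic ring here is not enough on its own: compound 1 and compound 2 both carry one, yet compound 2 cannot be told apart from compound 3, which has none. Nothing available gives a reason for these numbers.

Going by these compounds, it remains open how other groups on the phenyl ring of compound 1, such as chlorine or methoxy, would read in this assay. Also open, on these data alone, is what a longer chain or an amine in place of methyl would do on this carbonyl carbon.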